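The compounds below may be only part of what the source reports. "The series", "measured", "known", "first", "only" and "open" are said of these compounds alone.

Compound 1 `CCC(CC)O[C@@H]1C=C(B(O)O)C[C@H](N)[C@H]1NC(C)=O` is recorded in an ADME assay on MDCK cells (Canis lupus familiaris) for cytotoxicity, with a stated time of 48 h (a lower number here means that less compound is tolerated, a higher number that more compound is tolerated), as "not determined" (no result reported), so it cannot be placed on a number in this assay. Compound 2 `CCC(CC)O[C@@H]1C=C(B(O)O)C[C@H](NC(=N)N)[C@H]1NC(C)=O` is likewise recorded in this assay as "not determined" (no result reported). Compound 3 `CCC(CC)O[C@@H]1C=C([S+]([O-])O)C[C@H](NC(=N)N)[C@H]1NC(C)=O` is reported in this assay only as a limit, > 100000 nM. Going by the values given here, the only value given is the limit of > 100000 nM in this assay, at which 1 of the 3 values shown sits, a limit rather than a measured number. Compound 4 `CCC(CC)O[C@@H]1C=C(S(=O)(=O)O)C[C@H](N)[C@H]1NC(C)=O` has not yet been measured; it differs from compound 1 by a group of 4 heavy atoms (3 oxygen, 1 sulfur; no ring) in place of a group of 3 heavy atoms (1 boron, 2 oxygen; no ring), on a double-bonded ring carbon. No step between measured compounds is shown in this assay, and there is nothing to point to a direction or size of change, so the expectation is none beyond the usual scatter. On that footing compound 4 is expected to give about 100000 nM, with a range from 50000 nM to 300000 nM.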

Compound 4, half-maximal cytotoxic concentration: > 100000 nM
Compound 4 was reported as a limit; the forecaster's own chance of this, stated with the estimate: 80%; the middle value sits exactly at the limit.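

No step can be read from compound 1 to compound 4, as compound 1 has no number in this assay and compound 4 gives only a limit, > 100000 nM. On these data alone, whether the sulfo group changes how much compound is tolerated stays open.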